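Replacing 3-(trifluoromethyl)pyrrolidin-1-yl in compound 3

This account rests on a few compounds, and the source may have more. Where it says the series, first, only, none or still open, it means among the compounds named here.

Values so far in an ADME assay on microsomes from liver (Mus musculus) for metabolic stability, read by LC-MS, using NADPH, with stated times of 10 min and 30 min, tested at 1 uM (on this read-out lower numbers stand for slow clearance and higher numbers for fast clearance), are these.
Compound 1 `COC(=O)C1=C(CN2CC3CC2CO3)NC(c2nccs2)=NC1(C)c1ccc(F)cc1` gives 84 mL/min/kg
Compound 2 `COC(=O)C1=C(CN2CCC(F)(F)CC2)NC(c2nccs2)=NC1(C)c1ccc(F)cc1` gives 88 mL/min/kg
Compound 3 `COC(=O)C1=C(CN2CCC(C(F)(F)F)C2)NC(c2nccs2)=NC1(C)c1ccc(F)cc1` gives 88 mL/min/kg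

Compound 3 (88 mL/min/kg) is level with compound 2 at the digits shown and within the scatter of compound 1. The next compound to be tested is compound 4 `COC(=O)C1=C(CN2CCCS2(=O)=O)NC(c2nccs2)=NC1(C)c1ccc(F)cc1` and it carries this change: a group of 7 heavy atoms (3 carbon, 1 nitrogen, 2 oxygen, 1 sulfur; one five-membered non-aromatic ring with 2 hetero atoms) in place of a group of 9 heavy atoms (5 carbon, 1 nitrogen, 3 fluorine; one five-membered non-aromatic ring with 1 hetero atom), on a saturated chain carbon bound to a double-bonded ring carbon in the same place as the earlier swaps. Among the compounds with values here, three measured steps bear on it: a 1.0-fold higher number from compound 1 to compound 2 (0.02 log units; within the scatter) and a 1.0-fold higher number from compound 1 to compound 3 (0.02 log units; within the scatter) and no change at the digits printed from compound 2 to compound 3 (within the scatter) all lie within the scatter. Within the data shown here, none of the measured compounds carries the entering group, so these steps are only a loose guide. In this assay the expected size is a 1.2-fold lower number from compound 3 to compound 4 (0.07 log units; within the scatter) and no step beyond the scatter is expected. Compound 4 is therefore estimated at 75 mL/min/kg (estimated range 40 mL/min/kg to 105 mL/min/kg).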

Compound 4, clearance in the Mus musculus assay: 79 mL/min/kg
Compound 4: middle estimate off by 1.1-fold (0.02 log units), on the low side; measured number inside the range.
By their numbers in the Mus musculus assay, from the lowest: compounds 4, 1, 2 and 3 (each within the scatter of the next).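

At this saturated chain carbon, the five-membered ring with 2 hetero atoms, which brings sulfur and carries no fluorine, fits the same flat picture in the Mus musculus assay, with a 1.1-fold lower number from compound 3 to compound 4 (0.05 log units; within the scatter) and a 1.1-fold lower number from compound 2 to compound 4 (0.05 log units; within the scatter) and a 1.1-fold lower number from compound 1 to compound 4 (0.03 log units; within the scatter) all within the scatter. Four different groups at this place therefore leave fast clearance where it stood, so the position has not yet shown any handle on this read-out. What is new is that the same swap does move another read-out beyond the scatter, with clearance held level, in a physicochemical assay for solubility, read by HPLC, in phosphate buffer, at pH 6.5; on this read-out higher numbers stand for higher solubility and lower numbers for lower solubility: the measured solubility of compound 3, 13 ug/mL, and of compound 4, 125 ug/mL, a 9.6-fold higher number (0.98 log units; beyond the scatter) In the physicochemical assay compound 3 gives 13 ug/mL and compound 4 gives 125 ug/mL.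

The compounds shown leave open whether a group of another kind at this place, such as a piperidine bearing a carboxylic acid, would bring the Mus musculus assay beyond the scatter of these numbers. They also leave open whether an open-chain methanesulfonamide in the same place would give the higher number in the physicochemical assay as the ring does.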